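The compounds below may be only part of what the source reports. "The series", "measured", "known", "first", "only" and "open" are said of these compounds alone.

In a functional assay on the whole organism for inhibition, with Mythimna separata as the target, with a stated time of 5 days (on this read-out higher numbers stand for an effect only at larger amounts of compound and lower numbers for an effect already at smaller amounts), the measured compounds gave the following numbers:

Compound 1 `Cc1ccc(-c2nnc(COc3cnn(C(C)(C)C)c(=O)c3Cl)o2)cc1`: 19900 nM
Compound 2 `Cc1nnc(COc2cnn(C(C)(C)C)c(=O)c2Cl)o1` gives only a limit: > 299000 nM
Compound 3 `COc1ccc(-c2nnc(COc3cnn(C(C)(C)C)c(=O)c3Cl)o2)cc1`: 17700 nM

Compound 3 shows the lowest of the two numbers reported, but it is not separated from compound 1, since a 1.1-fold lower number from compound 1 to compound 3 (0.05 log units; within the scatter). Compound 2 sits at the limit of > 299000 nM in this assay, at which 1 of the 3 values shown sits.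

Compound 4 `CC(C)(C)n1ncc(OCc2nnc(-c3ccc(Cl)cc3F)o2)c(Cl)c1=O` differs from compound 3 in one place: 4-chloro-2-fluorophenyl in place of 4-methoxyphenyl on an aromatic carbon.

Two kinds of measured step bear on this change. Removing the whole aryl ring matters a great deal: an at least 15-fold higher number from compound 1 to compound 2 (1.17 log units; beyond the scatter), and an at least 16-fold lower number from compound 2 to compound 3 (1.22 log units; beyond the scatter). Exchanging one small group on that ring, by contrast, matters little: a 1.1-fold lower number from compound 1 to compound 3 (0.05 log units; within the scatter). For the measured compounds named here, compound 4 keeps the aryl ring and only changes its substituents, from a methoxy to a chlorine and a fluorine, a swap that no measured pair covers directly. On this basis the step in this assay is expected to be small, a 1.1-fold lower number from compound 3 to compound 4 (0.04 log units; within the scatter), with no clear direction.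

Compound 4 is therefore estimated at 16000 nM, with a plausible range from 5000 nM to 50000 nM.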

Compound 4, half-maximal effective concentration: 10400 nM
The estimate for compound 4 lay 1.5-fold (0.19 log units) above the measured number; low and high end bracket the measured number.
By their numbers in this assay, from the lowest: compounds 4, 3 and 1 (each within the scatter of the next). At a limit, above all of these: compound 2.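

With a third aryl group at this position, the picture from compounds 1 and 3 now extends to a ring that carries chlorine and fluorine and has no oxygen. In this assay, the two steps between aryl compounds that include this new ring, a 1.7-fold lower number from compound 3 to compound 4 (0.23 log units; within the scatter) and a 1.9-fold lower number from compound 1 to compound 4 (0.28 log units; within the scatter), both stay within the scatter, so the three substituted phenyl rings cannot be told apart here, while the step away from methyl is large: an at least 28-fold lower number from compound 2 to compound 4 (1.45 log units; beyond the scatter). Compound 2, the one compound without an aryl ring and so the exception among the four, gives only a limit of the assay: the limit of > 299000 nM in this assay, at which 1 of the 4 values shown sits.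

Compound 4 changes its ring in more than one way at once, so the compounds shown cannot separate what the chlorine and the fluorine each contribute, and 4-chlorophenyl and 2-fluorophenyl would be needed to do so. From the compounds shown here alone, it also stays open whether an aromatic ring of carbon only is needed at all, or whether plain phenyl, a pyridine ring, a cyclohexyl ring or a longer chain such as hexyl would serve as well as these rings.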